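Swapping the Aryl Group on a Sulfonamide

This account rests on a few compounds, and the source may have more. Where it says the series, first, only, none or still open, it means among the compounds named here.

Compound 1 `CN(C(=O)c1ccccn1)c1ccc(C(O)(C(F)(F)F)C(F)(F)F)cc1` gives > 100000 nM in an ADME assay on Li23 cells (Homo sapiens) for cytotoxicity, read by WST assay; on this read-out higher numbers stand for lower toxicity in this test and lower numbers for higher toxicity in this test; this is a limit of the assay, not a number.
Compound 2 `CN(c1ccc(C(O)(C(F)(F)F)C(F)(F)F)cc1)S(=O)(=O)c1ccccc1Br` gives 9100 nM in this assay.

Going by the values given here, compound 2 thus holds the only real number among the values shown, and compound 1 sits at the limit of > 100000 nM in this assay, at which 1 of the 2 values shown sits. The two compounds differ in several places at once, so their values can only be placed side by side, not turned into a measured step.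

Compound 3 `Cc1cccc(S(=O)(=O)N(C)c2ccc(C(O)(C(F)(F)F)C(F)(F)F)cc2)c1` has not been measured. It differs from compound 2 in one place: 3-methylphenyl in place of 2-bromophenyl on a sulfonyl sulfur. Among the compounds with values here, no measured step of this kind is available to lean on. The expected step is therefore small, with a slight lean toward a higher number, within the usual scatter: from compound 2 to compound 3 the estimate means a 1.4-fold higher number from compound 2 to compound 3 (0.15 log units; within the scatter). For compound 3 the expected value in this assay is 13000 nM, with a likely range from 4500 nM to 40000 nM.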

Compound 3, half-maximal cytotoxic concentration: 11000 nM
Beside the measured number, compound 3's estimate is 1.2-fold (0.07 log units) above it; the range from low to high includes it.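

In this assay, going by these compounds alone, this is the first step that can be read at this position: putting 3-methylphenyl in place of 2-bromophenyl on the sulfonyl sulfur gives a 1.2-fold higher number from compound 2 to compound 3 (0.08 log units; within the scatter). A bromine and a methyl group are different substituents, yet this read-out does not separate the two aryl groups that carry them. No measurement shown bears on why the two compounds read alike.

As far as these compounds go, it remains open whether a phenyl ring carrying an amine or a carboxylic acid, or a longer alkyl chain in place of the aryl group, would give a different value. Compound 1 differs from the sulfonamides in several places and its > 100000 nM is a limit of the assay, so which of those differences matters also stays unresolved.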